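The compounds below may be only part of what the source reports. "The series", "measured", "known", "first", "only" and "open" are said of these compounds alone.

In a functional assay on MCF7 cells (Homo sapiens) for cytotoxicity, read by MTT assay, with a stated time of 48 h (a higher number here means a weaker inhibitor of growth, a lower number a stronger inhibitor of growth), compound 2 (`CC(C)n1c(C(F)(F)F)nc2cc(Cl)c(Cl)cc21`) gives 70500 nM. Compound 1 (`CC(C)c1nc2cc(Cl)c(Cl)cc2[nH]1`) gives 57000 nM, within the scatter of compound 2, while compound 3 (`O=[N+]([O-])c1ccccc1Cn1c(C(F)(F)F)nc2cc(Cl)c(Cl)cc21`) gives a far lower 1500 nM, well beyond the scatter. Compound 2 therefore shares the high end of these numbers with compound 1.

Compound 4 (`FC(F)(F)c1nc2cc(Cl)c(Cl)cc2n1C1CCCC1`) has cyclopentyl in place of isopropyl on an aromatic nitrogen. Going by the values given here, no measured pair shows this change directly. Among the compounds with values here, compound 3, at 1500 nM, shows only that another group on that nitrogen can come with a much lower number. A modest step toward a lower number is expected, a 2.4-fold lower number from compound 2 to compound 4 (0.37 log units; beyond the scatter). For compound 4 the estimated value is 30000 nM, with an expected range from 10000 nM to 75000 nM.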

Compound 4, concentration for 50% growth inhibition: 21000 nM
Estimate against measurement, compound 4: 1.4-fold (0.15 log units) above; the range from low to high includes it.
By their numbers in this assay, from the lowest: compound 3; then compound 4; then compounds 1 and 2 (each within the scatter of the next).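

Cyclopentyl in place of isopropyl on the aromatic nitrogen brings a 3.4-fold lower number from compound 2 to compound 4 (0.53 log units; beyond the scatter) in this assay and so gives the first direct reading of a change at this position. A group of carbon only, with no hydrogen-bond donors or acceptors, can thus lower the number, although compound 3 at 1500 nM still lies far lower than compound 4. No measured property is available to explain this step.

As far as these compounds go, whether cyclohexyl or a longer chain such as butyl on that nitrogen would lower the number further stays open. So does the outcome of a chain carrying an amine there.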